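The compounds below may be only part of what the source reports. "The series", "measured", "known", "first", "only" and "open" are said of these compounds alone.

Compound 1 `Oc1cccc(-c2cc(-c3cccnc3)nc(-c3ccccc3Cl)c2)c1` and compound 2 `Oc1cccc(-c2cc(-c3ccsc3)nc(-c3ccccc3Cl)c2)c1` share one core and differ in a single place. In an assay on isolated protein for inhibition of DNA topoisomerase 1 (Homo sapiens), with a stated time of 30 min, tested at 100 uM (a lower number here means a weaker effect, a higher number a stronger effect of the compound at the concentration tested), compound 1 gives 0%, and in this assay compound 2 gives 0%. The step of no change at the digits printed from compound 1 to compound 2 (within the scatter), thiophen-3-yl in place of pyridin-3-yl on an aromatic carbon, left the read-out where it was. Compound 2 thus stands level with compound 1, with no effect seen at the concentration tested.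

Compound 3 `Oc1cccc(-c2cc(-c3ccco3)nc(-c3ccccc3Cl)c2)c1` has not yet been measured; it differs from compound 2 by furan-2-yl in place of thiophen-3-yl on an aromatic carbon. For the measured compounds named here, only the step from compound 1 to compound 2 bears on this change, and that step showed no movement beyond the scatter, so a step of no change at the digits printed from compound 2 to compound 3 (within the scatter) is expected, again nothing beyond the scatter. Compound 3 is estimated to give 0% in this assay, within a range of 0% to 12%.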

Compound 3, a percentage reported as inhibition, at one concentration (the size of the read-out at that concentration, not a potency): 0%
For compound 3 middle estimate and measured number coincide at the digits printed, within the range that was stated.
By their numbers in this assay, from the lowest: compounds 1, 2 and 3 (each within the scatter of the next).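

With furan-2-yl on the aromatic carbon next to the ring nitrogen, this assay shows no change at the digits printed from compound 2 to compound 3 (within the scatter) and also no change at the digits printed from compound 1 to compound 3 (within the scatter), so this position has now carried three aromatic rings rather than two. Pyridin-3-yl, thiophen-3-yl and furan-2-yl differ in their hetero atom, and the two five-membered rings also differ in how they are attached, yet none of these differences moves the read-out beyond the scatter. No other data here speak to the reason for this result.

With no effect seen for any of the three compounds, they cannot tell whether this position can influence the read-out at all. Going by these compounds, an amine, a carboxylic acid or a longer chain at this position remains open, as do changes to the 3-hydroxyphenyl and 2-chlorophenyl groups.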